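Ethoxycarbonyl to carboxy: compound 2 to compound 4

This account rests on a few compounds, and the source may have more. Where it says the series, first, only, none or still open, it means among the compounds named here.

Measured so far in a functional assay on MDA-MB-231 cells (Homo sapiens) for inhibition, read by sulforhodamine B assay, with a stated time of 72 h (on this read-out lower numbers stand for stronger inhibition of growth and higher numbers for weaker inhibition of growth), for this series
Compound 1 `CN1CCN(C(=O)/C=C/c2ccncc2-c2ccc3ccccc3c2)CC1` gives > 10000 nM (a limit)
Compound 2 `CCOC(=O)/C=C/c1ccncc1-c1ccc2c(cnn2C)c1` gives > 10000 nM (a limit)
Compound 3 `CCOC(=O)/C=C/c1ccncc1-c1ccc2ccccc2c1` gives 8090 nM (a number)

Compound 2 stands at > 10000 nM in this assay and this is a limit, not a number. The next structure is compound 4 `Cn1ncc2cc(-c3cnccc3/C=C/C(=O)O)ccc21` and the change is hydrogen in place of ethyl on an oxygen next to a carbonyl group. Among the compounds with values here, the one measured step at a comparable carbonyl is an at least 1.2-fold lower number from compound 1 to compound 3 (0.09 log units; that floor lies within the scatter) and it exchanges a different group. Within the data shown here, no measured step covers this exchange itself. The series also crowds at the limit of > 10000 nM in this assay, at which 2 of the 3 values shown sit, and compound 2 is already there, leaving little room to read a size or direction. No step beyond the scatter is expected, and the estimated step is a step that the limit leaves unreadable from compound 2 to compound 4 for now. For compound 4 the estimate is 15000 nM with an expected range from 6000 nM to 40000 nM and a report as a limit is likely.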

Compound 4, concentration for 50% growth inhibition: > 10000 nM
Compound 4 ended at the assay's limit; the forecaster's own chance of this, stated with the estimate: 80%; the middle value lies beyond the limit too.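

No step can be read from compound 2 to compound 4, as both values are limits and not numbers: the limit of > 10000 nM in this assay, at which 3 of the 4 values shown sit.

The compounds shown leave open whether hydrogen in place of ethyl on this oxygen changes growth inhibition at all, in either direction or by any size.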